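Swapping Chloro for Amino on Two Related Cores

The compounds below may be only part of what the source reports. "The series", "measured", "known", "first", "only" and "open" are said of these compounds alone.

Compound 1 `O=c1cc(-c2ccc(Cl)cc2)oc2ccc(CN3CCCCC3)cc12` and compound 2 `Nc1ccc(-c2cc(=O)c3cc(CN4CCCCC4)ccc3o2)cc1` share one core, while compound 3 `Cc1ccc2c(=O)cc(-c3ccc(Cl)cc3)oc2c1` and the as yet unmeasured compound 4 `Cc1ccc2c(=O)cc(-c3ccc(N)cc3)oc2c1` share another; the difference between the two cores is not broken down here. In a functional assay on HepG2 cells (Homo sapiens) for cytotoxicity, read by MTT assay, with a stated time of 48 h (on this read-out higher numbers stand for weaker inhibition and lower numbers for stronger inhibition), compound 1 gives 14000 nM, compound 2 gives 2640 nM and compound 3 gives 6830 nM. The change amino in place of chloro on an aromatic carbon produced a 5.3-fold lower number from compound 1 to compound 2 (0.72 log units; beyond the scatter). The same change is now made on the second core, (amino in place of chloro on an aromatic carbon), and the place of the change is described identically in both cases. A step of similar size is expected from compound 3 to compound 4, a 4.6-fold lower number from compound 3 to compound 4 (0.66 log units; beyond the scatter), because compound 1 and compound 2 showed a 5.3-fold lower number from compound 1 to compound 2 (0.72 log units; beyond the scatter). Compound 4 is therefore expected to give about 1500 nM in this assay, with a likely range from 600 nM to 4000 nM.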

Compound 4, half-maximal inhibitory concentration: 40500 nM
Compound 4: middle estimate off by 27-fold (1.43 log units), on the low side; the measured number lies above the stated range.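

In this assay, amino in place of chloro on an aromatic carbon gave a 5.9-fold higher number from compound 3 to compound 4 (0.77 log units; beyond the scatter), so on this core the number rose instead of falling. The size and direction of the step seen on one core therefore did not carry over to the other: the same change on two cores in this assay, a 5.3-fold lower number (0.72 log units; beyond the scatter) from compound 1 to compound 2 and a 5.9-fold higher number (0.77 log units; beyond the scatter) from compound 3 to compound 4, 31-fold (1.50 log units) apart, beyond the scatter of two such steps. Among these compounds, this shows that the change cannot be assumed to act alike on these two cores, but with only one pair on each core it does not show why the steps part ways or how the change would act on any further core.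

The compounds shown leave open how other groups in the same place, such as a hydroxyl or a methoxy group, would behave on the two cores. They also leave open which part of the difference between the cores decides the direction of the step.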